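The compounds below may be only part of what the source reports. "The series", "measured", "known", "first", "only" and "open" are said of these compounds alone.

Measured in a functional assay on HT-29 cells (Homo sapiens) for inhibition; a higher number here means a weaker inhibitor, a lower number a stronger inhibitor:
- Compound 1 `Nc1n[n+]([O-])c2cc(Cl)ccc2[n+]1[O-]`: 19800 nM
- Compound 2 `Nc1n[n+]([O-])c2cc(C(F)(F)F)ccc2[n+]1[O-]`: 79100 nM

Compound 2 holds the higher of the two numbers, which makes it the weaker inhibitor of this pair. For the measured compounds named here, its only neighbour is compound 1.

Compound 3 `Nc1n[n+]([O-])c2cc([N+](=O)[O-])ccc2[n+]1[O-]` keeps the shared core and carries nitro in place of trifluoromethyl on an aromatic carbon. Going by the values given here, one measured step bears on this change: a 4.0-fold higher number from compound 1 to compound 2 (0.60 log units; beyond the scatter), modest in size, for trifluoromethyl in place of chloro on an aromatic carbon. Among the compounds with values here, that step shows that the number can move with the group at this place, but nothing measured so far covers nitro, so the direction is only weakly supported.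

A step of similar modest size is expected in this assay, more likely towards a lower number, since compound 2 stands at the high end with 79100 nM. The estimated step is a 3.2-fold lower number from compound 2 to compound 3 (0.50 log units; beyond the scatter). For compound 3 the estimated value is 25000 nM, with an expected range of 6000 nM to 90000 nM.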

Compound 3, half-maximal inhibitory concentration: 14100 nM
Estimate against measurement, compound 3: 1.8-fold (0.25 log units) above, within the range that was stated.
By their numbers in this assay, from the lowest: compounds 3 and 1 (each within the scatter of the next); then compound 2.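

In this assay, this position now has a second step beyond the scatter, a 5.6-fold lower number from compound 2 to compound 3 (0.75 log units; beyond the scatter), so trifluoromethyl stands apart from nitro as well as from chloro, and compound 2 is the weakest inhibitor of the three. Nitro and chloro cannot be separated on this aromatic carbon, as a 1.4-fold lower number from compound 1 to compound 3 (0.15 log units; within the scatter) lies within the scatter, so the change from chloro to nitro gives no measurable difference here. Nothing available explains why trifluoromethyl is separated from the other two groups.

The compounds shown leave open how an amine, a carboxylic acid or a longer chain on this aromatic carbon would read in this assay, and whether any group here can give a number clearly lower than those of compound 1 and compound 3. Also open, as far as these compounds go, is whether trifluoromethyl stays apart from chloro and nitro when these groups sit on another carbon of the same ring, or when the amine on the shared core is replaced by another group.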